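The source may report more compounds than this note shows. Statements on the series, on what has been measured and on what is new or still open speak of the compounds shown alone.

Series notes. In a functional assay on CHO cells for agonist activity at Free fatty acid receptor 1 (Homo sapiens), read by a luciferase reporter (a lower number here means a smaller maximal response, a higher number a larger maximal response), compound 1 `O=C(O)/C=C/c1ccc(NCc2cccc(Oc3ccccc3)c2)cc1` gives 76%, compound 2 `CC(C)(Oc1ccc(NCc2cccc(Oc3ccccc3)c2)cc1)C(=O)O` gives 14% and compound 3 `CC(Cc1ccc(NCc2cccc(Oc3ccccc3)c2)cc1)C(=O)O` gives 70%. Compound 3 is second highest of the three numbers, though its gap to compound 1 is within the scatter; a number 6 percentage points lower from compound 1 to compound 3 (within the scatter), whereas a number 56 percentage points higher from compound 2 to compound 3 (beyond the scatter) and a number 62 percentage points lower from compound 1 to compound 2 (beyond the scatter) are large. Compound 4 `CC(CC(=O)O)c1ccc(NCc2cccc(Oc3ccccc3)c2)cc1` differs from compound 3 by 1-(carboxymethyl)ethyl in place of 2-carboxypropyl on an aromatic carbon. Among the compounds with values here, no measured pair repeats this rearrangement; the nearest comparison is compound 1 against compound 3, where the chain changed with little effect, and the large steps belong to the 1-carboxy-1-methylethoxy group of compound 2, which compound 4 lacks. In this assay only a small step is therefore expected for compound 4, a number 5 percentage points lower from compound 3 to compound 4 (within the scatter). Compound 4 is estimated at 65%, between 45% and 85%.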

Compound 4, largest response reached (reported as percent of maximum), in percent of the reference or control that the assay uses: 83%
The estimate for compound 4 lay 18 percentage points below the measured number, and the stated range covers the measured number.
By their numbers in this assay, from the lowest: compound 2; then compounds 3, 1 and 4 (each within the scatter of the next, the first and the last beyond it).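

In this assay, the exchange of 2-carboxypropyl for 1-(carboxymethyl)ethyl on the aromatic carbon para to a large group keeps the same counts of atoms, yet it gives a step beyond the scatter (a number 13 percentage points higher from compound 3 to compound 4 (beyond the scatter)). The step to the 2-carboxyethenyl of compound 1 remains within the scatter (a number 7 percentage points higher from compound 1 to compound 4 (within the scatter)), while the step from the 1-carboxy-1-methylethoxy of compound 2 is large (a number 69 percentage points higher from compound 2 to compound 4 (beyond the scatter)). The attachment of this acid chain therefore matters at this position, though only modestly here.

On these data alone, whether an unbranched 2-carboxyethyl or a longer chain would hold this response remains open. Nothing available accounts for the step between compound 3 and compound 4.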